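Swapping the Side Chain for Carbamoyl: Expected Cytotoxicity

The source may hold more compounds than are shown below. What is called first, only, known or untested is meant among the compounds shown, and "the series" means these compounds.

Of the compounds shown here, three built on one shared core have been tested in an ADME assay on L02 cells (Homo sapiens) for cytotoxicity, read by MTT assay, with a stated time of 48 h; a higher number here means a weaker inhibitor, a lower number a stronger inhibitor. Compound 1 `O=C1CSC(=O)N1C[C@H]1CN(c2ccc(-n3cc(-c4ccccn4)cn3)c(F)c2)C(=O)O1` reaches only the assay limit, > 400 ug/mL. Compound 2 `CS(=O)(=O)NC[C@H]1CN(c2ccc(-n3cc(-c4ccccn4)cn3)c(F)c2)C(=O)O1` likewise reaches only a limit, > 400 ug/mL. Within the data shown here, compound 3 `COC(=O)NC[C@H]1CN(c2ccc(-n3cc(-c4ccccn4)cn3)c(F)c2)C(=O)O1` gives 71 ug/mL, the only true number among the three, reached by an at least 5.6-fold lower number from compound 1 to compound 3 (0.75 log units; beyond the scatter) and by an at least 5.6-fold lower number from compound 2 to compound 3 (0.75 log units; beyond the scatter), whereas a step that the two limits leave unreadable from compound 1 to compound 2. Compound 4 `NC(=O)[C@H]1CN(c2ccc(-n3cc(-c4ccccn4)cn3)c(F)c2)C(=O)O1` is not yet measured and differs from compound 3 by carbamoyl in place of ((methoxycarbonyl)amino)methyl on a saturated ring carbon. Among the measured compounds shown here, no measured step matches this change, so only the two steps into compound 3 bear on it, and both show compound 3 alone sitting at a real number (the limit of > 400 ug/mL in this assay, at which 2 of the 3 values shown sit). Compound 4 is therefore expected to move back toward that limit, a 2.8-fold higher number from compound 3 to compound 4 (0.45 log units; beyond the scatter). Compound 4 is estimated at 200 ug/mL, within 60 ug/mL to 400 ug/mL.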

Compound 4, half-maximal inhibitory concentration: 119 ug/mL
Beside the measured number, compound 4's estimate is 1.7-fold (0.23 log units) above it; the measured number falls inside the stated range.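

In this assay, exchanging ((methoxycarbonyl)amino)methyl for carbamoyl on this saturated ring carbon makes no clear difference: a 1.7-fold higher number from compound 3 to compound 4 (0.22 log units; within the scatter). The smaller carbamoyl group therefore also gives a true number, which sets compound 4 apart from the other two side chains: an at least 3.3-fold lower number from compound 2 to compound 4 (0.52 log units; beyond the scatter), and an at least 3.3-fold lower number from compound 1 to compound 4 (0.52 log units; beyond the scatter). Compound 1 and compound 2 offer only a limit, not a number: the limit of > 400 ug/mL in this assay, at which 2 of the 4 values shown sit.

Going by these compounds, it remains open whether an amine or a carboxylic acid on this ring carbon would also give a true number or would return to the limit.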